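Dropping the chlorine from a small phenol

This account rests on a few compounds, and the source may have more. Where it says the series, first, only, none or still open, it means among the compounds named here.

Of the compounds shown here, three have been measured so far. Compound 1 `OCc1cc(OCc2cc(O)ccc2O)ccc1O` gives 6200 nM in a functional assay; on this read-out lower numbers stand for stronger inhibition and higher numbers for weaker inhibition. Compound 2 `COCc1cc(O)c(Cc2cc(O)ccc2O)cc1O` gives 6300 nM in this assay, and compound 3 `COCc1cc(O)cc(Cl)c1O` gives 8500 nM in this assay. Compound 3 sits at the upper end of these three numbers, yet its distance to compound 2 and to compound 1 lies within the usual scatter of repeated measurements, so the three cannot be told apart on this read-out.

The next compound, compound 4 `COCc1cc(O)ccc1O`, differs from compound 3 in one place: hydrogen in place of chloro on an aromatic carbon. Among the measured compounds shown here, no measured pair here shows what this kind of change does, so the expectation rests only on the three numbers above. Because compound 3 gives 8500 nM, the step from compound 3 to compound 4 in this assay is expected to be small, a 1.4-fold higher number from compound 3 to compound 4 (0.15 log units; within the scatter), and most likely toward weaker inhibition or none beyond the scatter. Compound 4 is thus estimated at 12000 nM, with a range from 5000 nM to 30000 nM.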

Compound 4, half-maximal inhibitory concentration: 9800 nM
Estimate against measurement, compound 4: 1.2-fold (0.09 log units) above; the range from low to high includes it.
By their numbers in this assay, from the lowest: compounds 1, 2, 3 and 4 (each within the scatter of the next).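

In this assay, among the compounds shown here, hydrogen in place of chloro on the aromatic carbon ortho to a hydroxy group gives a 1.2-fold higher number from compound 3 to compound 4 (0.06 log units; within the scatter) and provides the first direct comparison of a single change in this set. At this position, the chloro group can therefore be removed without a shift that this read-out can separate from repeat-measurement scatter, so this pair gives no sign that it matters for the inhibition seen here. No measurement shown explains this result.

Going by these compounds, whether another group at this position, such as an amine, a carboxylic acid or a longer chain, would produce a step beyond the scatter remains open. Also open, on these data alone, is whether the same chloro-to-hydrogen change would behave alike on the larger frameworks of compound 1 and compound 2.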